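The source may report more compounds than this note shows. Statements on the series, on what has been measured and on what is new or still open speak of the compounds shown alone.

Compound 1 `Cc1cc(-c2ccc(C(=O)N(C)c3ccccc3C)o2)ccc1OS(N)(=O)=O`: 570 nM
Compound 2 `Cc1ccccc1N(C)C(=O)c1ccc(-c2ccc(OS(N)(=O)=O)cc2F)o1`: 12 nM
Compound 3 `Cc1cccc(F)c1N(C)C(=O)c1ccc(-c2ccc(OS(N)(=O)=O)cc2)o1`: 150 nM

Of the compounds shown here, three have been measured in an assay on T47D cells for inhibition of Steryl-sulfatase (Homo sapiens), read by HPLC, with a stated time of 24 h; on this read-out higher numbers stand for weaker inhibition and lower numbers for stronger inhibition. Compound 3 gives 150 nM, which places it second highest of the three numbers. Compound 1 stands at the higher number with 570 nM, and compound 2 at the far lower number with 12 nM; both gaps to compound 3 lie beyond the scatter. Compounds 1 and 2 each differ from compound 3 at more than one place, so none of these gaps isolates a single change.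

The unmeasured compound 4 `Cc1cc(F)ccc1N(C)C(=O)c1ccc(-c2ccc(OS(N)(=O)=O)cc2)o1` differs from compound 3 in one place only: 4-fluoro-2-methylphenyl in place of 2-fluoro-6-methylphenyl on an amide-type nitrogen. The same atoms are kept and only joined differently on the ring carried by the amide-type nitrogen. For the measured compounds named here, no measured pair shows the effect of such a rearrangement, so the step from compound 3 to compound 4 is expected to be a 1.3-fold lower number from compound 3 to compound 4 (0.10 log units; within the scatter) in this assay, within the usual scatter. Compound 4 is accordingly estimated at 120 nM, in a range from 30 nM to 500 nM.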

Compound 4, half-maximal inhibitory concentration: 14 nM
Compound 4: the middle estimate sits 8.6-fold (0.93 log units) above what was measured, outside the stated range (below it).
By their numbers in this assay, from the lowest: compounds 2 and 4 (each within the scatter of the next); then compound 3; then compound 1.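

In this assay, 4-fluoro-2-methylphenyl in place of 2-fluoro-6-methylphenyl on the amide-type nitrogen gives an 11-fold lower number from compound 3 to compound 4 (1.03 log units; beyond the scatter). For the compounds shown here, this is the first step that isolates a single place, and it shows that this ring is highly sensitive to how its atoms are arranged, even though its atom count stays the same. Nothing available explains the size of this step.

The compounds leave open whether the fluorine of 4-fluoro-2-methylphenyl could be replaced by chlorine or a methoxy group with a similar result. They also do not show whether the same rearrangement would have a similar effect on the core of compound 2, which differs from compound 4 at more than one place.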